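The source may hold more compounds than are shown below. What is called first, only, known or untested is meant among the compounds shown, and "the series" means these compounds.

Measured so far:
compound 1 `COc1ccc2c(c1)OC(c1cc(OC)c(OC)c(OC)c1)C(C=O)=C2` — 13500 nM
compound 2 `COc1ccc2c(c1)OC(c1cc(OC)c(OC)c(OC)c1)C(C#N)=C2` — 3400 nM

Both were tested in a functional assay for inhibition of nuclear factor NF-kappa-B complex (Homo sapiens); on this read-out lower numbers stand for stronger inhibition and higher numbers for weaker inhibition. Going by the values given here, compound 1 stands highest of the two numbers; its nearest neighbour is compound 2, and a 4.0-fold lower number from compound 1 to compound 2 (0.60 log units; beyond the scatter) is the only step in this set, a modest gain that comes from a change at the same double-bonded ring carbon that is varied next. Compound 3 `COc1ccc2c(c1)OC(c1cc(OC)c(OC)c(OC)c1)C(CO)=C2` has not been measured; it differs from compound 1 as follows: hydroxymethyl in place of formyl on a double-bonded ring carbon. Among the compounds with values here, no measured pair exchanges a formyl for a hydroxymethyl, so the one step from cyano bears only loosely on this change: it shows that a different group at this ring carbon can move the number, but cyano and hydroxymethyl have little in common. The account therefore expects, for compound 3, no step beyond the scatter in this assay in either direction, with a wide range to reflect the missing precedent. The step the estimate implies is a 1.1-fold higher number from compound 1 to compound 3 (0.05 log units; within the scatter), expected rather than measured. For compound 3 the estimate in this assay is 15000 nM, within a range from 5000 nM to 45000 nM.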

Compound 3, half-maximal inhibitory concentration: > 50000 nM
Compound 3: no number, only a limit; the forecaster's own chance of this, stated with the estimate: 15%; middle value at least 3.3-fold (0.52 log units) away from the limit.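

The result for compound 3 is a limit of the assay and not a number: the limit of > 50000 nM in this assay, at which 1 of the 3 values shown sits. Even so, this assay gives an at least 3.7-fold higher number from compound 1 to compound 3 (0.56 log units; beyond the scatter), and the change from cyano gives an at least 14-fold higher number from compound 2 to compound 3 (1.16 log units; beyond the scatter). Going by these compounds alone, the earlier compounds showed only that this double-bonded ring carbon can give a lower number, whereas the number now moves in both directions from the formyl compound, and it does so on an exchange in which formyl and hydroxymethyl have the same count of heavy atoms, with hydroxymethyl adding a hydrogen-bond donor.

Going by these compounds, how far the true number for compound 3 lies past the limit stays unknown, so the full size of both steps stays open. The compounds shown also cannot tell whether the hydrogen-bond donor goes with the weaker inhibition or whether some other difference between the groups does, and a methoxymethyl group, an aminomethyl group or a carboxylic acid on this ring carbon would bear on that question.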